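Amide aryl variation in the shared core: compound 4

A few compounds are considered here, and "the series" means these few. Any claim that something is new, unique, unknown or untested is made for them only; others in the source may bear on it.

Measured so far in a functional assay on HEK293 cells for positive allosteric modulation of metabotropic glutamate receptor 5 (Homo sapiens), read by calcium flux; a lower number here means a smaller maximal response, a higher number a larger maximal response:
compound 1 `O=C(c1ccc(F)cc1)N1CCc2nc(COc3ccccc3F)oc2C1`: 78%
compound 2 `O=C(c1ccc(F)cc1)N1CCc2nc(COc3cccc(F)c3)oc2C1`: 78%
compound 3 `O=C(c1ccc(F)cc1)N1CCc2nc(COc3ccccn3)oc2C1`: 75%

Compound 2 stands level with compound 1, the two together at the top of three numbers that all lie within the scatter of one another: no change at the digits printed from compound 1 to compound 2 (within the scatter), a number 3 percentage points lower from compound 2 to compound 3 (within the scatter), a number 3 percentage points lower from compound 1 to compound 3 (within the scatter).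

Compound 4 `O=C(c1c(F)cccc1F)N1CCc2nc(COc3cccc(F)c3)oc2C1` differs from compound 2 at the carbonyl carbon: 2,6-difluorophenyl in place of 4-fluorophenyl on a carbonyl carbon. Every measured step varies the group on the oxygen on a saturated carbon and leaves the group on the carbonyl carbon untouched, so none bears directly on this change. The data give no reason for a step beyond the scatter in either direction. Compound 4 is therefore expected to give about 76%, with a range of 60% to 90%. The expected step is a number 2 percentage points lower from compound 2 to compound 4 (within the scatter).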

Compound 4, largest response reached (reported as percent of maximum), in percent of the reference or control that the assay uses: 82%
Compound 4: the middle estimate sits 6 percentage points below what was measured, and the stated range covers the measured number.
By their numbers in this assay, from the lowest: compounds 3, 1, 2 and 4 (each within the scatter of the next).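

In this assay, the group on the carbonyl carbon now has its first measured step: 2,6-difluorophenyl in place of 4-fluorophenyl gives a number 4 percentage points higher from compound 2 to compound 4 (within the scatter), so this change leaves the maximal response within the scatter with 3-fluorophenyl on the oxygen on a saturated carbon. No measurement at hand bears on why the response holds at this position.

Still open, on these data alone, is how an unsubstituted phenyl, a cyclohexyl or a morpholine on the carbonyl carbon would read out. Also open, as far as these compounds go, is whether 2,6-difluorophenyl behaves the same with pyridin-2-yl on the oxygen on a saturated carbon.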